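From dimethylphenyl to dichlorophenyl on a shared core

The source may report more compounds than this note shows. Statements on the series, on what has been measured and on what is new or still open speak of the compounds shown alone.

Compound 1 `CCOc1ccc(-n2nncc2CN2C(=O)C3(C(C#N)=C(N)Oc4c3c3nc5ccccc5nc3c3ccccc43)c3ccccc32)cc1` in an ADME assay on HUVEC cells (Homo sapiens) for antiproliferative activity, read by MTT assay, with a stated time of 48 h (a lower number here means a stronger inhibitor, a higher number a weaker inhibitor), gives > 50000 nM, which is a limit of the assay.
Compound 2 `N#CC1=C(N)Oc2c(c3nc4ccccc4nc3c3ccccc23)C12C(=O)N(Cc1cnnn1-c1ccc([N+](=O)[O-])cc1)c1ccccc12` in this assay gives > 50000 nM, again a limit of the assay.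
Compound 3 `Cc1ccc(-n2nncc2CN2C(=O)C3(C(C#N)=C(N)Oc4c3c3nc5ccccc5nc3c3ccccc43)c3ccccc32)c(C)c1` in this assay gives > 50000 nM, also a limit of the assay.

Compound 3 therefore stands where every measured compound stands, at a limit rather than a number: the limit of > 50000 nM in this assay, at which 3 of the 3 values shown sit. Compound 4 `N#CC1=C(N)Oc2c(c3nc4ccccc4nc3c3ccccc23)C12C(=O)N(Cc1cnnn1-c1ccc(Cl)c(Cl)c1)c1ccccc12` differs from compound 3 in one place: 3,4-dichlorophenyl in place of 2,4-dimethylphenyl on an aromatic nitrogen. The measured steps that change the same aryl group, a step that the two limits leave unreadable from compound 1 to compound 3 and a step that the two limits leave unreadable from compound 2 to compound 3, together with a step that the two limits leave unreadable from compound 1 to compound 2, all run between limits and cannot be read, so they give neither a direction nor a size. The expectation for compound 4 is the same outcome, a step of a number no higher from compound 3 to compound 4 (the limit leaves the size open) that most likely ends at a limit again. Compound 4 is estimated at 50000 nM, with a range from 20000 nM to 200000 nM.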

Compound 4, half-maximal inhibitory concentration: > 50000 nM
Compound 4: only a limit was reported; the forecaster's own chance of this, stated with the estimate: 85%; the middle value sits exactly at the limit.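

No step between compound 1, compound 2, compound 3 and compound 4 can be read, since each value is a limit and not a number: the limit of > 50000 nM in this assay, at which 4 of the 4 values shown sit.

Left open is whether any aryl group on the shared core gives a true number in this assay, and how these groups rank.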